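The compounds below may be only part of what the source reports. "The series", "measured", "known", "first", "only" and "open" are said of these compounds alone.

Measured compounds:
- Compound 1, `CCc1ccc(-c2nc(-c3ccccc3OC)sc2CC(=O)O)cc1`: in an in vitro assay on COS-7 cells for displacement of a labelled ligand from prostaglandin D2 receptor 2 (Homo sapiens) (a lower number here means a stronger inhibitor, a higher number a weaker inhibitor), compound 1 gives 1400 nM.
- Compound 2, `COc1ccc(-c2nc(-c3ccc(OC)cc3)c(CC(=O)O)s2)cc1`: in this assay compound 2 gives 4100 nM.
- Compound 3, `O=C(O)Cc1sc(Cc2ccccc2)nc1-c1ccc(Cl)cc1`: in this assay compound 3 gives 180 nM.

Compound 3 stands lowest of the three numbers and is therefore the strongest inhibitor among them. Its nearest neighbour is compound 1, whose number is higher by a margin beyond the scatter, and the furthest is compound 2, again beyond the scatter. Among the compounds with values here, the three compounds share a core carrying an acetic acid side chain, and none of them differs from another in a single place, so no step between measured compounds can be read off.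

Compound 4, `O=C(O)Cc1sc(Cc2ccc(Cl)cc2)nc1-c1ccc(Cl)cc1`, is not yet measured. It differs from compound 3 by chloro in place of hydrogen on an aromatic carbon. Within the data shown here, no measured pair shows this change. The expectation rests on the structural difference alone, which is small. A step of at most modest size is expected, most likely none beyond the scatter, with a slight lean toward a lower number. Compound 4 is therefore expected to give about 150 nM in this assay, with a range from 60 nM to 450 nM. That estimate means an expected step of a 1.2-fold lower number from compound 3 to compound 4 (0.08 log units; within the scatter), which is expected to lie within the scatter.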

Compound 4, half-maximal inhibitory concentration: 50 nM
Estimate against measurement, compound 4: 3.0-fold (0.48 log units) above; measured number below the stated range.
By their numbers in this assay, from the lowest: compound 4; then compound 3; then compound 1; then compound 2.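

Within the data shown here, compound 3 and compound 4 form the first pair here that differs in only one place, so the effect of a single substituent can now be read directly. In this assay, the change from benzyl to 4-chlorobenzyl gives a 3.6-fold lower number from compound 3 to compound 4 (0.56 log units; beyond the scatter), a modest step, but one that lies beyond the scatter, which shows that this aromatic carbon, para to a large group, is not indifferent to the entry of a single chlorine atom. No measurement shown here accounts for this step, which therefore stands as an observation without an established cause.

The compounds shown leave open whether the step belongs to chloro in particular or would also appear with fluoro, bromo, methyl or methoxy on the same aromatic carbon, and whether chloro on another carbon of this ring would give a step of similar size. They also leave open whether the same change would give a similar step if the 4-chlorophenyl group on the shared core were replaced by an unsubstituted phenyl or if the acetic acid side chain were replaced by a longer chain.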